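From a Fluorophenyl Urea to a Dichlorophenyl Urea

The compounds below may be only part of what the source reports. "The series", "measured", "known", "first", "only" and "open" are said of these compounds alone.

Compound 1 `CN(C)CCCNc1nc(-c2ccc(NC(=O)Nc3ccccc3F)cc2)nc2ccsc12`: 730 nM
Compound 2 `CN(C)CCCNc1nc(-c2ccc(NC(=O)Nc3ccc(Cl)cc3)cc2)nc2c(Cl)c(Cl)sc12`: 1530 nM

Of the compounds shown here, two have been tested in a functional assay on MKN-45 cells (Homo sapiens) for cytotoxicity, read by MTT assay, with a stated time of 72 h; on this read-out higher numbers stand for weaker inhibition and lower numbers for stronger inhibition. Compound 1 gives 730 nM, the lowest of the two numbers, while compound 2 gives 1530 nM, a higher number that lies beyond the usual scatter. Compound 3 `CN(C)CCCNc1nc(-c2ccc(NC(=O)Nc3ccc(Cl)cc3Cl)cc2)nc2ccsc12` has not been measured; it differs from compound 1 by 2,4-dichlorophenyl in place of 2-fluorophenyl on an amide-type nitrogen. Among the compounds with values here, no measured pair isolates this change, so its effect is unknown. In this assay the change is expected to give a 1.3-fold higher number from compound 1 to compound 3 (0.11 log units; within the scatter), a small shift toward a higher number. For compound 3 the estimate is 950 nM, ranging from 320 nM to 2800 nM.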

Compound 3, half-maximal inhibitory concentration: 2270 nM
For compound 3 the middle estimate is 2.4-fold (0.38 log units) below the measured one, within the range that was stated.
By their numbers in this assay, from the lowest: compound 1; then compounds 2 and 3 (each within the scatter of the next).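

In this assay, placing 2,4-dichlorophenyl in place of 2-fluorophenyl on the amide-type nitrogen gives a 3.1-fold higher number from compound 1 to compound 3 (0.49 log units; beyond the scatter) and so weaker inhibition. Within the data shown here, this is the first single-place comparison at this position, and it shows that the group on this nitrogen affects the read-out. Nothing available here explains the shift.

The compounds shown leave open how a plain phenyl or a 2-chlorophenyl on the same nitrogen would read, and so whether losing the fluorine or gaining the chlorines matters more.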